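One Aromatic Swap, One Expected Rise

The source may report more compounds than this note shows. Statements on the series, on what has been measured and on what is new or still open speak of the compounds shown alone.

Two measured compounds share a common core. Compound 1 `Cc1nn(C)c(Oc2ccc(Cl)cc2)c1/C=N/OCc1ccc([N+](=O)[O-])cc1` gives 27.1% in a functional assay on MCF7 cells (Homo sapiens) for antiproliferative activity, tested at 1 uM; a higher number here means more inhibition at the concentration tested (going by the name of the read-out), a lower number less inhibition. Compound 2 `COc1cccc(CO/N=C/c2c(C)nn(C)c2Oc2ccccc2)c1` stands lowest of the two numbers, giving 8.4% in this assay, a gap to compound 1 that lies beyond the usual scatter. Compound 3 `Cc1nn(C)c(Oc2ccccc2)c1/C=N/OCc1ccc([N+](=O)[O-])cc1` is not yet measured; it differs from compound 2 by 4-nitrophenyl in place of 3-methoxyphenyl on a saturated chain carbon bound to an oxygen on an unsaturated carbon. Within the data shown here, no single-change step between measured compounds is available, but compound 1, bearing the same 4-nitrophenyl, gives 27.1%, which points upward. The step expected here is a number 12.6 percentage points higher from compound 2 to compound 3 (beyond the scatter), a rise beyond the scatter. Compound 3 is expected to reach 21%, between 6% and 36%.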

Compound 3, a percentage reported as inhibition, at one concentration (the size of the read-out at that concentration, not a potency): 24%
Compound 3: the middle estimate sits 3 percentage points below what was measured; the range from low to high includes it.
By their numbers in this assay, from the lowest: compound 2; then compounds 3 and 1 (each within the scatter of the next).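

In this assay, the change of 3-methoxyphenyl to 4-nitrophenyl on the saturated chain carbon can now be read directly as a single change, giving a number 15.6 percentage points higher from compound 2 to compound 3 (beyond the scatter). The chloro on the aromatic carbon, by contrast, shows no effect beyond the scatter when hydrogen takes its place, giving a number 3.1 percentage points lower from compound 1 to compound 3 (within the scatter). Nothing measured explains the rise that comes with 4-nitrophenyl.

As far as these compounds go, whether an amine or a carboxylic acid on that aromatic ring in place of the nitro group would move the number stays open. So does whether chloro would also leave the number unchanged alongside 3-methoxyphenyl.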